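Moving the methoxy group: a small step expected

This account rests on a few compounds, and the source may have more. Where it says the series, first, only, none or still open, it means among the compounds named here.

In a functional assay on A549 cells (Homo sapiens) for cytotoxicity, read by sulforhodamine B assay, with a stated time of 48 h (a lower number here means a stronger inhibitor, a higher number a weaker inhibitor), compound 3 (`COc1ccccc1/C=C/C(=O)c1cccc(-c2cccc(F)c2)c1`) gives 15500 nM and stands within the scatter of both other measured compounds. In this assay compound 1 (`COc1ccc(/C=C/C(=O)c2cccc(-c3ccc(F)cc3)c2)cc1`) reads 11200 nM and compound 2 (`O=C(/C=C/c1cccc(Br)c1)c1cccc(-c2cccc(F)c2)c1`) reads 9120 nM on the same scale, so the three values form one tight group.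

The change now in question leads to compound 4 (`COc1ccc(/C=C/C(=O)c2cccc(-c3cccc(F)c3)c2)cc1`), which has 4-methoxyphenyl in place of 2-methoxyphenyl on a double-bonded chain carbon bound to a double-bonded chain carbon.

For the measured compounds named here, only one measured step alters the group at this place, namely a 1.7-fold higher number from compound 2 to compound 3 (0.23 log units; within the scatter) on exchanging 3-bromophenyl for 2-methoxyphenyl, and it lies within the scatter. Compound 1 already bears 4-methoxyphenyl at that place and reads 11200 nM in this assay without leaving the group, although it is not otherwise identical to compound 4.

On this evidence the expected change is a 1.3-fold lower number from compound 3 to compound 4 (0.11 log units; within the scatter) and no step beyond the scatter is expected. In this assay the estimated value for compound 4 is 12000 nM (expected range from 6000 nM to 24000 nM).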

Compound 4, half-maximal inhibitory concentration: 2440 nM
Compound 4: the middle estimate sits 4.9-fold (0.69 log units) above what was measured; measured number below the stated range.
By their numbers in this assay, from the lowest: compound 4; then compounds 2, 1 and 3 (each within the scatter of the next).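

In this assay, the group on a double-bonded chain carbon bound to a double-bonded chain carbon turns out to matter more than the earlier within-scatter step suggested: with the same atoms joined differently, 4-methoxyphenyl in place of 2-methoxyphenyl gives a 6.4-fold lower number from compound 3 to compound 4 (0.80 log units; beyond the scatter), and 4-methoxyphenyl in place of 3-bromophenyl gives a 3.7-fold lower number from compound 2 to compound 4 (0.57 log units; beyond the scatter). The gain from 4-methoxyphenyl also depends on the other end of the molecule, since 3-fluorophenyl in place of 4-fluorophenyl on an aromatic carbon gives a 4.6-fold lower number from compound 1 to compound 4 (0.66 log units; beyond the scatter), so among these compounds the lowest number appears only when 4-methoxyphenyl and 3-fluorophenyl occur together. No measurement at hand accounts for either change.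

The compounds shown leave open how a 3-methoxyphenyl, a 4-hydroxyphenyl or a 4-dimethylaminophenyl group would read at this place alongside 3-fluorophenyl. They also leave open whether exchanging 4-fluorophenyl for 3-fluorophenyl would shift the number in the same way with 2-methoxyphenyl or 3-bromophenyl on the chain, or whether that shift belongs to 4-methoxyphenyl alone.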